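From Bromo to Hydroxy: A Small Step Expected

This account rests on a few compounds, and the source may have more. Where it says the series, first, only, none or still open, it means among the compounds named here.

Of the compounds shown here, three sharing one core have been tested in a functional assay on PANC-1 cells (Homo sapiens) for inhibition, read by MTT assay, with a stated time of 24 h; on this read-out higher numbers stand for weaker inhibition and lower numbers for stronger inhibition. Compound 1 `Cc1ccc(-n2cc(CN3C(=O)C[C@@H]4CC[C@@]3(C)C4(C)C)nn2)cc1` carries a methyl on its aromatic ring and gives 270 nM. Compound 2 `CC1(C)[C@H]2CC[C@]1(C)N(Cc1cn(-c3ccccc3)nn1)C(=O)C2` has a hydrogen in that place and gives 160 nM. Compound 3 `CC1(C)[C@H]2CC[C@]1(C)N(Cc1cn(-c3ccc(Br)cc3)nn1)C(=O)C2` carries a bromo there and gives 200 nM. Compound 3 stands second highest of the three numbers, yet all three lie within the scatter of one another, so none of them can be called stronger or weaker than the others. The steps measured so far are a 1.7-fold lower number from compound 1 to compound 2 (0.23 log units; within the scatter), a 1.4-fold lower number from compound 1 to compound 3 (0.13 log units; within the scatter) and a 1.3-fold higher number from compound 2 to compound 3 (0.10 log units; within the scatter): each exchange at this place has stayed within the scatter.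

Compound 4 `CC1(C)[C@H]2CC[C@]1(C)N(Cc1cn(-c3ccc(O)cc3)nn1)C(=O)C2` differs from compound 3 by hydroxy in place of bromo on an aromatic carbon. Within the data shown here, no measured step involves a hydroxy, so nothing bears directly on this swap. What the three steps do show is that methyl, hydrogen and bromo at this place all give similar numbers in this assay, which suggests the place tolerates exchange. The expectation for compound 4 is therefore a 1.1-fold higher number from compound 3 to compound 4 (0.04 log units; within the scatter), a step not beyond the scatter. Compound 4 is estimated at 220 nM, with a range from 80 nM to 600 nM.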

Compound 4, half-maximal inhibitory concentration: 100 nM
The estimate for compound 4 lay 2.2-fold (0.34 log units) above the measured number, and the stated range covers the measured number.
By their numbers in this assay, from the lowest: compounds 4, 2, 3 and 1 (each within the scatter of the next, the first and the last beyond it).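

Hydroxy is the first group at this place to bring a hydrogen-bond donor and acceptor, as bromo brings neither, yet in this assay it stays within the scatter of both bromo (a 2.0-fold lower number from compound 3 to compound 4 (0.30 log units; within the scatter)) and hydrogen (a 1.6-fold lower number from compound 2 to compound 4 (0.20 log units; within the scatter)). Against methyl, however, it gives the first step at this place that passes beyond the scatter (a 2.7-fold lower number from compound 1 to compound 4 (0.43 log units; beyond the scatter)), though only modestly, so the four compounds now show a real, if small, difference at a position where every earlier exchange had stayed within the scatter. No measurement shown here gives a reason for this difference.

Still open, from the compounds shown here alone, is how far this position's tolerance extends, since an amine or a carboxylic acid on the same aromatic carbon, or a longer chain such as propoxy, could behave quite differently from the small groups seen so far. A methoxy at this place would also help to show whether the hydrogen of the hydroxy matters to the number, or whether the oxygen alone gives the same result.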